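The source may report more compounds than this note shows. Statements on the series, on what has been measured and on what is new or still open speak of the compounds shown alone.

In an ADME assay on Vero cells (Chlorocebus sabaeus) for antiproliferative activity, read by MTT assay (on this read-out higher numbers stand for weaker inhibition and lower numbers for stronger inhibition), compound 1 `Fc1ccc(N2CCN(c3nc(-n4ccc5ccccc54)c4ccccc4n3)CC2)cc1` gives 50 ug/mL and compound 2 `Cn1cc(-c2nc(N3CCNCC3)nc3ccccc23)c2ccccc21` gives 50 ug/mL on the same read-out, so compound 2 stands level with compound 1 within the scatter. Compound 3 `CN1CCN(c2nc(-c3cn(C)c4ccccc34)c3ccccc3n2)CC1` carries methyl in place of hydrogen on an amine nitrogen in a ring and so turns piperazin-1-yl into 4-methylpiperazin-1-yl. Within the data shown here, no measured pair shows this change, so no step beyond the scatter is expected in this assay and no direction is favoured. The estimated step is no change at the digits printed from compound 2 to compound 3 (within the scatter). Compound 3 is estimated at 50 ug/mL with an expected range of 25 ug/mL to 100 ug/mL on that read-out.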

Compound 3, half-maximal inhibitory concentration: 50 ug/mL
The estimate for compound 3 equals the measured number at the digits printed; low and high end bracket the measured number.
By their numbers in this assay, from the lowest: compounds 1, 2 and 3 (each within the scatter of the next).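

In this assay, among these compounds, the change from piperazin-1-yl to 4-methylpiperazin-1-yl reads as no change at the digits printed from compound 2 to compound 3 (within the scatter) and gives the first look at substitution on this amine nitrogen in a ring. Methyl in place of hydrogen is accepted here without a step beyond the scatter. Nothing at hand accounts for this result. Still open, from the compounds shown here alone, is whether a group larger than methyl on the same nitrogen, such as an acetyl group, a longer alkyl chain or a chain ending in a carboxylic acid, would leave the read-out level as well.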